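Leucine side chain swapped for an aminoethyl chain

The source may hold more compounds than are shown below. What is called first, only, known or untested is meant among the compounds shown, and "the series" means these compounds.

Measured so far:
compound 1, `CC(C)C[C@H](NC(=O)c1ccc(Cl)c(Cl)c1)C(=O)N[C@H]1CCN(Cc2ccc(OCCCN(C)C)cc2)C1`, 126 nM in an assay on HEK293 cells for binding affinity to Urotensin-2 receptor (Homo sapiens), read by radioligand binding; a lower number here means a stronger inhibitor, a higher number a weaker inhibitor
compound 2, `CC(C)C[C@H](NC(=O)c1ccccc1)C(=O)N[C@H]1CCN(Cc2ccc(OCCCN(C)C)cc2)C1`, 501 nM in this assay

Compound 1 gives the lower of the two numbers measured in this assay; its nearest neighbour is compound 2, reached by a 4.0-fold higher number from compound 1 to compound 2 (0.60 log units; beyond the scatter) through the exchange of the aryl group on the carbonyl carbon. Compound 3, `CN(C)CCCOc1ccc(CN2CC[C@H](NC(=O)[C@H](CCCN)NC(=O)c3ccc(Cl)c(Cl)c3)C2)cc1`, keeps the dichlorophenyl of compound 1 and differs only in the side chain: 2-aminoethyl in place of isopropyl on a saturated chain carbon, two bonds along the chain from an amide-type nitrogen and a carbonyl carbon. For the measured compounds named here, the one measured step touches the aryl group and not the side chain, so it gives no direct guide to this change; a branched alkyl chain is replaced by a chain of equal length ending in an amine, and nothing measured here shows how this assay responds to that. Compound 3 is therefore expected to stay within a modest distance of compound 1, most likely a 2.4-fold higher number from compound 1 to compound 3 (0.38 log units; beyond the scatter), with a wide band on either side. The estimate for compound 3 in this assay is 300 nM, within 60 nM to 1500 nM.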

Compound 3, inhibition constant: < 10000 nM
Compound 3 was reported as a limit (the forecaster's own chance of this, stated with the estimate: 5%); the middle value lies beyond the limit too.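

In this assay, for the compounds shown here, compound 3 is reported only as a limit, < 10000 nM, so no step from compound 1 to compound 3 can be read. The compounds shown leave open how far 2-aminoethyl in place of isopropyl shifts the number in this assay, and whether the same exchange would shift it equally with the phenyl of compound 2.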